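The source may hold more compounds than are shown below. What is called first, only, known or untested is meant among the compounds shown, and "the series" means these compounds.

Measured so far in a functional assay on MCF7 cells (Homo sapiens) for inhibition, read by MTT assay, with a stated time of 2 days; on this read-out lower numbers stand for stronger inhibition and higher numbers for weaker inhibition:
- compound 1 `Oc1ccc(/C=C/c2ccccc2O)cc1` gives 21 ug/mL
- compound 2 `Nc1ccccc1/C=C/c1cccc(O)c1` gives 17 ug/mL
- compound 3 `Nc1ccccc1/C=C/c1ccc(O)cc1` gives 79 ug/mL

Compound 3 holds the highest number of the three. Its nearest neighbour is compound 1, reached by a 3.8-fold higher number from compound 1 to compound 3 (0.58 log units; beyond the scatter); compound 2 stands further off, beyond the scatter as well.

The next compound, compound 4 `COc1ccccc1/C=C/c1ccc(O)cc1`, differs from compound 3 in one place: methoxy in place of amino on an aromatic carbon.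

Going by the values given here, no measured step in this assay exchanges amino for methoxy, so nothing bears on the change directly. Among the compounds with values here, the only step touching the same carbon is a 3.8-fold higher number from compound 1 to compound 3 (0.58 log units; beyond the scatter), which shows that the group at this carbon moves the number by a modest amount when hydroxy becomes amino. Methoxy shares with hydroxy one oxygen, but carries no hydrogen-bond donor, so neither compound 1 nor compound 3 is a clean reference. The expectation is therefore a step of modest size from compound 3 to compound 4 in this assay, most likely toward a lower number, but with a range wide enough to include no change beyond the scatter.

Compound 4 is estimated at 45 ug/mL with a range of 15 ug/mL to 130 ug/mL, that is, an expected step of a 1.8-fold lower number from compound 3 to compound 4 (0.24 log units; within the scatter).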

Compound 4, half-maximal inhibitory concentration: 19 ug/mL
Compound 4: the middle estimate sits 2.4-fold (0.37 log units) above what was measured; low and high end bracket the measured number.
By their numbers in this assay, from the lowest: compounds 2, 4 and 1 (each within the scatter of the next); then compound 3.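

In this assay, a 4.2-fold lower number from compound 3 to compound 4 (0.62 log units; beyond the scatter) runs opposite to a 3.8-fold higher number from compound 1 to compound 3 (0.58 log units; beyond the scatter), so at this aromatic carbon, with the rest of the core held as in compound 3, amino gives the high number and both oxygen-linked groups give numbers within the scatter of each other. The new comparison, a 1.1-fold lower number from compound 1 to compound 4 (0.04 log units; within the scatter), shows that methyl in place of hydrogen on that oxygen does not move the number beyond the scatter, even though methoxy enters with 0 hydrogen-bond donors. No available measurement explains why the amino compound stands apart from the two oxygen-linked compounds.

The link between amino and a high number holds only for this pair of comparisons and does not extend across the series: compound 2 also carries amino and gives 17 ug/mL, so amino alone does not set the number. Still open, as far as these compounds go, is whether a longer ether such as ethoxy, a dimethylamino group or an acetamide at this carbon would stay with compound 1 and compound 4 or move toward compound 3.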